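Coumarin amide series: tertiary amine side chain variation

The source may hold more compounds than are shown below. What is called first, only, known or untested is meant among the compounds shown, and "the series" means these compounds.

Compound 1 `CC(C)=CCc1cc(C(=O)Nc2cc3ccc(OCC4CCN(C)C4)c(C)c3oc2=O)ccc1O` is the lower of the two measured numbers in a functional assay on MCF7 cells (Homo sapiens) for antiproliferative activity (a lower number here means a stronger inhibitor, a higher number a weaker inhibitor), where compound 1 gives 1550 nM. Going by the values given here, compound 2 `CC(C)=CCc1cc(C(=O)Nc2cc3ccc(OCCCNCC(=O)O)c(C)c3oc2=O)ccc1O` gives 18100 nM in this assay, and the only measured step, a 12-fold higher number from compound 1 to compound 2 (1.07 log units; beyond the scatter), runs toward weaker inhibition. Compound 3 `CC(C)=CCc1cc(C(=O)Nc2cc3ccc(OCCCN(C)C4CCCCC4)c(C)c3oc2=O)ccc1O` carries the change (2-(cyclohexyl(methyl)amino)ethyl in place of 1-methylpyrrolidin-3-yl on a saturated chain carbon bound to an oxygen on an aromatic ring). The measured step does not bear directly on this change, since it puts 2-((carboxymethyl)amino)ethyl in place of the same leaving group, not 2-(cyclohexyl(methyl)amino)ethyl; it shows only that this position can move the number a great deal. Among the compounds with values here, with no step pointing in either direction, compound 3 is expected to stay close to compound 1, a 1.2-fold lower number from compound 1 to compound 3 (0.08 log units; within the scatter), within the scatter. The estimate for compound 3 in this assay is therefore 1300 nM, with a range from 400 nM to 4500 nM.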

Compound 3, half-maximal inhibitory concentration: 1080 nM
Compound 3: the middle estimate sits 1.2-fold (0.08 log units) above what was measured; the range from low to high includes it.
By their numbers in this assay, from the lowest: compounds 3 and 1 (each within the scatter of the next); then compound 2.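

In this assay, the step of a 1.4-fold lower number from compound 1 to compound 3 (0.16 log units; within the scatter) stays within the scatter, so (1-methylpyrrolidin-3-yl)methoxy and 3-(cyclohexyl(methyl)amino)propoxy cannot be told apart at this position, despite their different rings and chain lengths. The step of a 17-fold lower number from compound 2 to compound 3 (1.22 log units; beyond the scatter) gives the (carboxymethyl)amino side chain a second large comparison, so compound 2 now stands apart from both compound 1 and compound 3. No measured evidence gives a cause for either step.

Going by these compounds, it remains open whether the higher number of compound 2 follows the carboxylic acid itself or the secondary amine that carries it, which a methyl ester or a simple secondary amine on the same chain would separate. Also open, on these data alone, is how a morpholine or a longer chain would fare at this position.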